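Ester variation on a cyclohexyl nitroanilide series

A few compounds are considered here, and "the series" means these few. Any claim that something is new, unique, unknown or untested is made for them only; others in the source may bear on it.

Values in a functional assay on MCF7 cells (Homo sapiens) for inhibition, read by MTT assay, with a stated time of 72 h; on this read-out higher numbers stand for weaker inhibition and lower numbers for stronger inhibition:

compound 1 `O=C(OC1(C(=O)Nc2ccc([N+](=O)[O-])cc2)CCCCC1)c1ccc(Cl)cc1` gives 15 nM
compound 2 `COc1ccc(C(=O)OC2(C(=O)Nc3ccc([N+](=O)[O-])cc3)CCCCC2)cc1` gives 41.2 nM
compound 3 `CCOC(=O)c1ccccc1C(=O)OC1(C(=O)Nc2ccc([N+](=O)[O-])cc2)CCCCC1` gives 444 nM

Compound 2 holds the second highest of the three numbers in this assay. Within the data shown here, its nearest neighbour is compound 1, reached through the step of a 2.7-fold higher number from compound 1 to compound 2 (0.44 log units; beyond the scatter); its furthest is compound 3, for which no single-site step is defined, so the two values stand side by side only: compound 2 gives 41.2 nM while compound 3 gives 444 nM.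

Compound 4 `O=C(/C=C/c1ccccc1)OC1(C(=O)Nc2ccc([N+](=O)[O-])cc2)CCCCC1` differs from compound 2 by 2-phenylethenyl in place of 4-methoxyphenyl on a carbonyl carbon. Among the measured compounds shown here, no measured step touches this kind of change; the only single-site step available, a 2.7-fold higher number from compound 1 to compound 2 (0.44 log units; beyond the scatter), swaps one substituent on the aromatic ring for another and is modest, and the remaining pair of values shows that a larger alteration of the ester group can move the number substantially. The expectation for this assay is therefore a step of modest size at most, with no firm direction, and a wide range around it. Compound 4 is expected to give 60 nM, between 20 nM and 200 nM, which would mean an expected step of a 1.5-fold higher number from compound 2 to compound 4 (0.16 log units; within the scatter).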

Compound 4, half-maximal inhibitory concentration: 57.6 nM
For compound 4 the middle estimate is 1.0-fold (0.02 log units) above the measured one, within the range that was stated.
By their numbers in this assay, from the lowest: compound 1; then compounds 2 and 4 (each within the scatter of the next); then compound 3.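

In this assay, 2-phenylethenyl in place of 4-methoxyphenyl on the carbonyl carbon gives a 1.4-fold higher number from compound 2 to compound 4 (0.15 log units; within the scatter), so at this position two groups of equal heavy-atom count, each with one aromatic ring, cannot be told apart, even though the entering group brings a double bond outside the ring and has no hydrogen-bond acceptor. Against 4-chlorophenyl, the same entering group gives a 3.8-fold higher number from compound 1 to compound 4 (0.58 log units; beyond the scatter), which places compound 1 apart from compound 4 as well as from compound 2, with a 2.7-fold higher number from compound 1 to compound 2 (0.44 log units; beyond the scatter) as the earlier step; among these three compounds, only the 4-chlorophenyl ester stands beyond the scatter of the others. No independent measurement bears on the reason for any of these steps.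

On these data alone, whether the double bond itself contributes remains open, since a saturated 2-phenylethyl group on the same carbonyl carbon would be needed to separate it from the aromatic ring it carries. Also open, as far as these compounds go, is whether a chloro group on the ring of the 2-phenylethenyl group would follow the difference seen for compound 1, and how an amine or a carboxylic acid on that ring would behave.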